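Adding one methyl to compound 2

This account rests on a few compounds, and the source may have more. Where it says the series, first, only, none or still open, it means among the compounds named here.

Measured so far in a functional assay on HT-29 cells (Homo sapiens) for antiproliferative activity, read by sulforhodamine B assay, with a stated time of 48 h (on this read-out higher numbers stand for weaker inhibition and lower numbers for stronger inhibition), the compounds read:
Compound 1 `CCc1ccccc1OS(=O)(=O)c1ccc(N2CCN(C)C2=O)cc1` gives 4600 nM
Compound 2 `CCCN1CCN(c2ccc(S(=O)(=O)Oc3ccccc3C)cc2)C1=O` gives > 100000 nM

Compound 2 stands with > 100000 nM as its entry, and this is a limit of the assay, not a number. Compound 3 `CCCN1CCN(c2ccc(S(=O)(=O)Oc3ccccc3CC)cc2)C1=O` has not yet been measured. It follows from compound 2 by a single change, methyl in place of hydrogen on a saturated chain carbon bound to an aromatic carbon, which turns 2-methylphenyl into 2-ethylphenyl. For the measured compounds named here, no measured step shows the size of this change. Compound 1, which also carries 2-ethylphenyl, gives 4600 nM in this assay, so a measurable value seems possible. The expected change is an at least 5.0-fold lower number from compound 2 to compound 3 (0.69 log units; beyond the scatter), towards stronger inhibition, though its size is uncertain. For compound 3 the estimated value is 20000 nM, with an expected range from 4000 nM to 100000 nM and no firmer footing.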

Compound 3, half-maximal inhibitory concentration: > 100000 nM
Compound 3 ended at the assay's limit (the forecaster's own chance of this, stated with the estimate: 35%); middle value at least 5.0-fold (0.69 log units) away from the limit.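

In this assay compound 3 reads > 100000 nM, which is a limit of the assay and not a number. With 2-ethylphenyl present in both compounds, ethyl in place of hydrogen on a saturated chain carbon bound to an amide-type nitrogen in a ring gives an at least 21-fold higher number from compound 1 to compound 3 (1.33 log units; beyond the scatter), so 2-ethylphenyl alone does not secure a measurable value here. The added methyl itself cannot be read as a step, because compound 2 and compound 3 stand at the same limit: the limit of > 100000 nM in this assay, at which 2 of the 3 values shown sit.

Going by these compounds, whether 2-methylphenyl and 2-ethylphenyl differ at all therefore stays open, and it could only be read on a pair that gives numbers. Also open, on these data alone, is what a chain of another kind on that ring nitrogen, such as an ethyl or a hydroxyethyl group, would give with 2-ethylphenyl in place.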